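The source may report more compounds than this note shows. Statements on the series, on what has been measured and on what is new or still open speak of the compounds shown alone.

Working notes on the series:

- Compound 1 `COc1cc(C(=O)c2sc3ccccc3c2-c2ccccc2)cc(OC)c1OC`: 1900 nM
- Compound 2 `COc1cc(C(=O)c2sc3ccccc3c2-c2ccc(C)cc2)cc(OC)c1OC`: 3700 nM

These values come from a functional assay on HeLa cells (Homo sapiens) for antiproliferative activity, read by MTT assay, with a stated time of 72 h; on this read-out lower numbers stand for stronger inhibition and higher numbers for weaker inhibition. Among the compounds with values here, compound 2, at 3700 nM, lies within the scatter of compound 1, the only other measured compound, so the two cannot be ranked.

Next in the series is compound 3 `COc1cc(C(=O)c2sc3ccccc3c2-c2ccc(SC)cc2)cc(OC)c1OC`, not yet measured. It has methylsulfanyl in place of methyl on an aromatic carbon, para to a large group, which reads as 4-methylphenyl to 4-(methylsulfanyl)phenyl: methylsulfanyl in place of methyl on an aromatic carbon.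

Within the data shown here, one measured step bears on this change. Methyl in place of hydrogen on an aromatic carbon gave a 1.9-fold higher number from compound 1 to compound 2 (0.29 log units; within the scatter), a step within the scatter. Among the measured compounds shown here, no measured compound carries methylsulfanyl, so the evidence is thin and the range has to stay wide. On the strength of that single small step, no shift beyond the scatter is expected in this assay, and the estimate is a 1.2-fold lower number from compound 2 to compound 3 (0.09 log units; within the scatter).

For compound 3 the expected value is 3000 nM, with an estimated range of 1000 nM to 9000 nM.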

Compound 3, half-maximal inhibitory concentration: 3500 nM
Compound 3: the middle estimate sits 1.2-fold (0.07 log units) below what was measured; low and high end bracket the measured number.
By their numbers in this assay, from the lowest: compounds 1, 3 and 2 (each within the scatter of the next).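

In this assay, the position para to a large group now carries a second substituent, and replacing methyl with methylsulfanyl, which brings in a sulfur, gives a 1.1-fold lower number from compound 2 to compound 3 (0.02 log units; within the scatter) with no separation between the two groups. Set against the parent hydrogen, methylsulfanyl gives a 1.8-fold higher number from compound 1 to compound 3 (0.27 log units; within the scatter) and so, like methyl, does not leave the scatter of compound 1; neither substituent at this position has yet produced a step that can be read as a real change. No accompanying measurement offers an explanation for this result.

The compounds shown leave open whether an amine, a carboxylic acid or a longer chain such as ethoxy at this position would give a step beyond the scatter, so the tolerance seen here rests on methyl and methylsulfanyl alone. They also leave open whether methylsulfanyl would give a similar number at another place on this six-membered aromatic ring.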